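Working notes: from compound 3 to compound 4

The source may report more compounds than this note shows. Statements on the series, on what has been measured and on what is new or still open speak of the compounds shown alone.

Measured compounds:
- compound 1, `COc1ccc(Nc2nc(SCc3cn(CC(=O)NC(=O)Nc4ccccn4)nn3)nc(-c3ccc(C(C)C)cc3)c2C#N)cc1`; in a functional assay on B16-F10 cells (Mus musculus) for inhibition, read by MTT assay, with a stated time of 72 h (on this read-out higher numbers stand for weaker inhibition and lower numbers for stronger inhibition), compound 1 gives 360 nM.
- compound 2, `COc1cc(-c2nc(SCc3cn(CC(=O)NC(=O)Nc4ccccn4)nn3)nc(Nc3ccc(C(C)C)cc3)c2C#N)cc(OC)c1OC`; compound 2 gives 1210 nM.
- compound 3, `Cc1ccc(-c2nc(SCc3cn(CC(=O)NC(=O)Nc4ccccn4)nn3)nc(Nc3ccc(C(C)C)cc3)c2C#N)cc1`; compound 3 gives 35 nM.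

Compound 3 holds the lowest number of the three, with compound 1 above it and compound 2 further above still, both gaps beyond the scatter. For the measured compounds named here, the only single-point step in the set, a 35-fold lower number from compound 2 to compound 3 (1.54 log units; beyond the scatter), concerns the aryl ring attached directly to the shared core.

Compound 4, `COc1ccc(Nc2nc(SCc3cn(CC(=O)NC(=O)Nc4ccccn4)nn3)nc(-c3ccc(C)cc3)c2C#N)cc1`, is not yet measured. It differs from compound 3 by methoxy in place of isopropyl on an aromatic carbon. Going by the values given here, no measured step bears on this site: the step from compound 2 to compound 3 changes the other aryl ring, and compound 1 differs from compound 3 in two places, so the gap between their numbers cannot be assigned to either change alone. The expectation for compound 4 therefore rests only on the numbers shown for compound 1 and compound 3 and carries wide uncertainty. A moderate rise in the number is expected for compound 4, a 2.6-fold higher number from compound 3 to compound 4 (0.41 log units; beyond the scatter). For compound 4 the estimate in this assay is 90 nM, within a range of 25 nM to 350 nM.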

Compound 4, half-maximal inhibitory concentration: 8750 nM
Beside the measured number, compound 4's estimate is 97-fold (1.99 log units) below it, outside the stated range (above it).
By their numbers in this assay, from the lowest: compound 3; then compound 1; then compound 2; then compound 4.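

In this assay, for the compounds shown here, the change from (4-isopropylphenyl)amino to (4-methoxyphenyl)amino, with the 4-methylphenyl on the shared core held constant, gives a 250-fold higher number from compound 3 to compound 4 (2.40 log units; beyond the scatter), so this substituent has a large effect on the number, which no earlier step could show. Going by these compounds alone, the second new step, with (4-methoxyphenyl)amino held constant, gives a 24-fold higher number from compound 1 to compound 4 (1.39 log units; beyond the scatter) for methyl in place of isopropyl on the aryl ring attached directly to the core, so that ring's substituent also matters in this setting, and each step removes the only isopropyl of the compound it starts from. Nothing given here explains either step.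

The shown compounds carry only isopropyl and methoxy on this aromatic carbon, so it remains open how a longer chain such as n-butyl, a halogen such as chlorine, or an amine such as dimethylamino would read here. Also open is whether the two rings act independently, as no compound shown carries isopropyl on both rings and the four compounds do not complete that pairing.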